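Chain diol in place of hydroxypropyl: expectation for compound 4

The source may hold more compounds than are shown below. What is called first, only, known or untested is meant among the compounds shown, and "the series" means these compounds.

Compound 2 `C[C@@H](O)CCn1nc2c(Br)c(Br)c(Br)c(Br)c2n1` gives 64% in a functional assay on MCF7 cells (Homo sapiens) for antiproliferative activity, read by MTT assay, with a stated time of 48 h, tested at 50 uM (a lower number here means a stronger effect, a higher number a weaker effect of the compound at the concentration tested), the highest of the three numbers. Compound 1 `OC(CCn1nc2c(Br)c(Br)c(Br)c(Br)c2n1)c1cccc(Cl)c1` gives 12% and compound 3 `OC(CCn1nc2c(Br)c(Br)c(Br)c(Br)c2n1)c1ccc(Br)cc1` gives 15%; both lie far below compound 2, beyond the scatter. Among the measured compounds shown here, the only measured step, a number 3 percentage points higher from compound 1 to compound 3 (within the scatter), concerns the aryl group and leaves the chain alcohol untouched. Compound 4 `OCC(O)Cn1nc2c(Br)c(Br)c(Br)c(Br)c2n1` differs from compound 2 by 1,2-dihydroxyethyl in place of 2-hydroxypropyl on a saturated chain carbon bound to an aromatic nitrogen. For the measured compounds named here, no measured pair bears on this change; there is no step for a second hydroxyl or for removal of the methyl. Like compound 2, compound 4 carries no ring in the chain, unlike compounds 1 and 3, so the number is expected to remain near that of compound 2. The expected step is a number 6 percentage points higher from compound 2 to compound 4 (within the scatter), within the scatter. Compound 4 is estimated at 70%, range 52% to 88%.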

Compound 4, a percentage reported as activity, at one concentration (the size of the read-out at that concentration, not a potency): 109%
Beside the measured number, compound 4's estimate is 39 percentage points below it; measured number above the stated range.
By their numbers in this assay, from the lowest: compounds 1 and 3 (each within the scatter of the next); then compound 2; then compound 4.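

In this assay, among the compounds shown here, this is the first step read on the saturated chain carbon bound to an aromatic nitrogen, and 1,2-dihydroxyethyl in place of 2-hydroxypropyl gives a number 45 percentage points higher from compound 2 to compound 4 (beyond the scatter), a large step. The position therefore responds strongly to a small change, and the absence of a ring in both chains does not keep their numbers together. Nothing available gives a reason for this step.

The compounds shown do not separate the added hydroxyl from the lost methyl or the lost defined stereocentre. From the compounds shown here alone, how a terminal amine, a carboxylic acid or a longer chain would read at this position remains open.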